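This account rests on a few compounds, and the source may have more. Where it says the series, first, only, none or still open, it means among the compounds named here.

Values in a functional assay on OVCAR-3 cells (Homo sapiens) for inhibition, read by MTT assay, with a stated time of 24 h; on this read-out higher numbers stand for weaker inhibition and lower numbers for stronger inhibition:
- compound 1 `CC1(C)[C@H]2CC[C@]1(C)N(Cc1cn(-c3ccc(C#N)cc3)nn1)C(=O)C2` gives 380 nM
- compound 2 `CC1(C)[C@H]2CC[C@]1(C)N(Cc1cn(-c3ccccc3F)nn1)C(=O)C2` gives 300 nM
- compound 3 `CC1(C)[C@H]2CC[C@]1(C)N(Cc1cn(-c3ccc(F)cc3)nn1)C(=O)C2` gives 200 nM

Compound 3 cannot be separated from the other two, since a 1.5-fold lower number from compound 2 to compound 3 (0.18 log units; within the scatter) and a 1.9-fold lower number from compound 1 to compound 3 (0.28 log units; within the scatter) are the gaps that set it apart. The next entry is compound 4 `CC1(C)[C@H]2CC[C@]1(C)N(Cc1cn(-c3ccc(O)cc3)nn1)C(=O)C2`, and the change is hydroxy in place of fluoro on an aromatic carbon, para to a large group. The nearest precedent is the exchange of cyano for fluoro, already given above, and the remaining measured step is a 1.3-fold lower number from compound 1 to compound 2 (0.10 log units; within the scatter). Among the compounds with values here, all three steps stay within the scatter, but none of the measured compounds carries hydroxy, so the direct evidence is thin. No direction is therefore expected in this assay, and no shift beyond the scatter. The estimated change is a 1.3-fold higher number from compound 3 to compound 4 (0.10 log units; within the scatter) and is not expected to exceed the scatter. For compound 4 the expected value is 250 nM, with an estimated range of 100 nM to 600 nM, kept wide for the untested group.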

Compound 4, half-maximal inhibitory concentration: 410 nM
Compound 4: the middle estimate sits 1.6-fold (0.21 log units) below what was measured; the measured number falls inside the stated range.
By their numbers in this assay, from the lowest: compounds 3, 2, 1 and 4 (each within the scatter of the next, the first and the last beyond it).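

In this assay, within the data shown here, hydroxy in place of fluoro on this aromatic carbon, para to a large group, gives the first step beyond the scatter, though a modest one (a 2.1-fold higher number from compound 3 to compound 4 (0.31 log units; beyond the scatter)). Compound 4 cannot be separated from the other two compounds (a 1.4-fold higher number from compound 2 to compound 4 (0.14 log units; within the scatter); a 1.1-fold higher number from compound 1 to compound 4 (0.03 log units; within the scatter)), so at this position hydroxy parts from fluoro, but not from the 2-fluorophenyl or 4-cyanophenyl variants. Among these compounds, only the pair of 4-fluorophenyl and 4-hydroxyphenyl is resolved, and no available measurement bears on a cause for this step.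

The compounds shown leave open whether a methoxy group, an amine or a carboxylic acid at the same place would read with fluoro or with hydroxy. They also leave open whether a 2-hydroxyphenyl group would differ from the 2-fluorophenyl group as the 4-substituted pair does.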